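This account rests on a few compounds, and the source may have more. Where it says the series, first, only, none or still open, it means among the compounds named here.

Compound 1, with the structure `Cn1c(-c2ccc(Br)cc2)cnc1NC(=O)c1ccc(F)cc1`, is the starting point here. Within the data shown here, in a toxicity assay on THP-1 cells (Homo sapiens) for inhibition (on this read-out higher numbers stand for lower toxicity in this test and lower numbers for higher toxicity in this test), compound 1 gives 46000 nM, the only plain number in this small set. Compound 2, `Cn1c(-c2ccc([N+](=O)[O-])cc2)cnc1NC(=O)c1ccc(F)cc1`, in this assay gives > 50000 nM, which is a limit of the assay and not a number. That limit is the limit of > 50000 nM in this assay, at which 1 of the 2 values shown sits. The step of an at least 1.0-fold higher number from compound 1 to compound 2 (0.03 log units; that floor lies within the scatter) goes with a nitro in place of bromo on an aromatic carbon.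

Compound 3, `Cn1c(-c2cccc(Br)c2)cnc1NC(=O)c1ccc(F)cc1`, has not yet been measured in this assay. Relative to compound 1 the change is 3-bromophenyl in place of 4-bromophenyl on an aromatic carbon. Among the measured compounds shown here, the only measured step, from compound 1 to compound 2, concerns a different change, a nitro in place of bromo, so it does not speak directly to this move, and it stays within the scatter in any case. With nothing to suggest a shift, the expected step is an estimated no change at the digits printed from compound 1 to compound 3 (within the scatter), meaning no change beyond the scatter. Compound 3 is therefore expected to give an estimated 46000 nM in this assay, with a range from 23000 nM to 92000 nM.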

Compound 3, half-maximal cytotoxic concentration: > 50000 nM
Compound 3 was reported as a limit; the forecaster's own chance of this, stated with the estimate: 40%; at least 1.0-fold (0.03 log units) between middle value and limit.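

The swap from 4-bromophenyl to 3-bromophenyl keeps the same atoms and changes only how the bromine sits on the phenyl ring, a question that the replacement of bromo by nitro in compound 2 did not address. In this assay this change gives an at least 1.0-fold higher number from compound 1 to compound 3 (0.03 log units; that floor lies within the scatter), so the read-out offers no sign that the new bromine placement brings higher toxicity, though it also shows no rise beyond the scatter. The result for compound 3 is a limit of the assay and not a number, and the two changes on this phenyl ring now end at the same ceiling: the limit of > 50000 nM in this assay, at which 2 of the 3 values shown sit.

As far as these compounds go, how far compound 3 really lies from compound 1 remains open, since a limit cannot show the size of any true difference. Also open, from the compounds shown here alone, is whether a group of another kind on this phenyl ring, such as an amine or a carboxylic acid, would bring the read-out down to a plain number lower than that of compound 1, which would show that this part of the molecule can affect toxicity in these cells at all.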